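Bromo in place of nitro on the sulfonamide of compound 3

A few compounds are considered here, and "the series" means these few. Any claim that something is new, unique, unknown or untested is made for them only; others in the source may bear on it.

Compound 1, `CCOC(=O)Cn1ncc2c(Nc3ccc(NC(=O)CCl)cc3)ncnc21`: in a functional assay on cells (Homo sapiens) for inhibition, read by MTT assay, with a stated time of 72 h (a lower number here means a stronger inhibitor, a higher number a weaker inhibitor), compound 1 gives 7.27 ug/mL.
Compound 2, `CCOC(=O)Cn1ncc2c(Nc3ccc(N)cc3)ncnc21`: in this assay compound 2 reaches only a limit, > 64 ug/mL.
Compound 3, `CCOC(=O)Cn1ncc2c(Nc3ccc(NS(=O)(=O)c4ccc([N+](=O)[O-])cc4)cc3)ncnc21`: in this assay compound 3 reaches only a limit, > 64 ug/mL.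

Compound 3 therefore stands at the limit of > 64 ug/mL in this assay, at which 2 of the 3 values shown sit. No number is known for it, only that it lies beyond the measured range.

Compound 4, `CCOC(=O)Cn1ncc2c(Nc3ccc(NS(=O)(=O)c4ccc(Br)cc4)cc3)ncnc21`, differs from compound 3 at one place: bromo in place of nitro on an aromatic carbon. Going by the values given here, the single measured step in this set, an at least 8.8-fold higher number from compound 1 to compound 2 (0.94 log units; beyond the scatter), concerns the removal of the (chloromethyl)carbonyl group at another place of the molecule and says nothing about the 4-nitrophenyl ring of compound 3. Among the compounds with values here, no measured step bears on the change from compound 3 to compound 4, so no shift beyond the scatter is expected, and the step that the limit leaves unreadable from compound 3 to compound 4 is estimated to be small. Compound 4 is expected to give about 80 ug/mL, somewhere from 30 ug/mL to 200 ug/mL, and most probably the assay will again report only a limit for compound 4.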

Compound 4, half-maximal inhibitory concentration: > 64 ug/mL
Compound 4: a limit, no number; the forecaster's own chance of this, stated with the estimate: 70%; the middle value is on the limit's open side.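

In this assay compound 4 gives > 64 ug/mL, which is a limit and not a number. Going from 4-nitrophenyl to 4-bromophenyl on the sulfonamide therefore yields no measured value at this position, and a second sulfonamide joins the compounds at the same limit: the limit of > 64 ug/mL in this assay, at which 3 of the 4 values shown sit. Going by these compounds alone, the steps to compound 4 from compound 2 and compound 3 cannot be read, so the only readable comparison is with the (chloromethyl)carbonyl group of the otherwise matching compound, where (4-bromophenyl)sulfonyl in its place gives an at least 8.8-fold higher number from compound 1 to compound 4 (0.94 log units; beyond the scatter).

The compounds shown leave open whether an amine or a carboxylic acid in place of bromo on the phenyl ring, or a longer chain in place of (chloromethyl)carbonyl, would give a measurable value. They also do not tell whether compound 3 and compound 4 differ at all.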